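A few compounds are considered here, and "the series" means these few. Any claim that something is new, unique, unknown or untested is made for them only; others in the source may bear on it.

Measured so far in a physicochemical assay for solubility, in phosphate buffer, measured as kinetic solubility, with a stated time of 24 h, at pH 6.5; a lower number here means a less soluble compound, a higher number a more soluble compound:
- compound 1 `CC(C)Oc1cc(Oc2ccc(S(C)(=O)=O)cc2)cc(-c2nccc(=O)[nH]2)c1` gives 25000 nM
- compound 2 `Cc1cc(=O)[nH]c(-c2cc(Oc3ccc(S(C)(=O)=O)cc3)cc(OC(C)C)c2)n1` gives 15000 nM

Within the data shown here, these are the only two numbers available, and they lie within the usual scatter of repeated measurements, so compound 2 stands level with compound 1 on this read-out.

Compound 3 `CCc1cnc(-c2cc(Oc3ccc(S(C)(=O)=O)cc3)cc(OC(C)C)c2)[nH]c1=O` has not yet been measured. It differs from compound 2 in one place: a group of 9 heavy atoms (6 carbon, 2 nitrogen, 1 oxygen; one six-membered aromatic ring with 2 hetero atoms) in place of a group of 8 heavy atoms (5 carbon, 2 nitrogen, 1 oxygen; one six-membered aromatic ring with 2 hetero atoms), on an aromatic carbon. The group that changes sits on an aromatic carbon of a six-membered aromatic ring of carbon only, and in both compounds it holds one six-membered aromatic ring with 2 hetero atoms.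

Among the measured compounds shown here, one measured step bears on this change: a 1.7-fold lower number from compound 1 to compound 2 (0.22 log units; within the scatter), which came with methyl in place of hydrogen on an aromatic carbon. That step stayed within the scatter, and a single step shows no trend. No change beyond the scatter is therefore expected in this assay. The expected step is a 1.3-fold lower number from compound 2 to compound 3 (0.10 log units; within the scatter). For compound 3 the estimated value is 12000 nM, with an expected range from 5000 nM to 25000 nM.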

Compound 3, solubility: 5700 nM
For compound 3 the middle estimate is 2.1-fold (0.32 log units) above the measured one, and the stated range covers the measured number.
By their numbers in this assay, from the lowest: compound 3; then compounds 2 and 1 (each within the scatter of the next).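

In this assay, the earlier pair gave only a 1.7-fold lower number from compound 1 to compound 2 (0.22 log units; within the scatter) and so left open whether a small alkyl group on the ring attached to the shared core could shift this read-out at all. The ethyl compound answers that. The change from the methyl-bearing group to the ethyl-bearing group comes with a 2.6-fold lower number from compound 2 to compound 3 (0.42 log units; beyond the scatter), and the comparison with the unsubstituted ring, ethyl in place of hydrogen, comes with a 4.4-fold lower number from compound 1 to compound 3 (0.64 log units; beyond the scatter) as well. Both steps are modest, yet together they show that this ring can take a small carbon substituent with a real drop in the number, while compound 3 still stays in the same broad range of values as the other two.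

On these data alone, with so few compounds, it remains open whether a longer chain such as propyl would lower the number further, or whether an amine or a carboxylic acid on the same ring would reverse the direction. Nothing shown here gives a measured reason for the step.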